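Ethoxymethyl Replaces Methyl on a Thioamide Core

The compounds below may be only part of what the source reports. "The series", "measured", "known", "first", "only" and "open" are said of these compounds alone.

Compound 1, `Cn1cc(C(N)=O)c2c(N)ncnc21`, in a functional assay on KB cells (Homo sapiens) for cytotoxicity; on this read-out higher numbers stand for weaker inhibition and lower numbers for stronger inhibition: > 100000 nM (a limit of the assay, not a number)
Compound 2, `Cn1cc(C(=N)S)c2c(N)ncnc21`, in this assay: 15000 nM

Compound 1 sits at the limit of > 100000 nM in this assay, at which 1 of the 2 values shown sits. Compound 2 holds the only real number shown, so it stands alone in this assay. Within the data shown here, the single measured step, an at least 6.6-fold lower number from compound 1 to compound 2 (0.82 log units; beyond the scatter), concerns the group on an aromatic carbon and says nothing about the other end of the molecule. Compound 3, `CCOCn1cc(C(=N)S)c2c(N)ncnc21`, differs from compound 2 by ethoxy in place of hydrogen on a saturated chain carbon bound to an aromatic nitrogen. Among the measured compounds shown here, no measured step touches that place, so no change beyond the scatter is expected; the expected step is no change at the digits printed from compound 2 to compound 3 (within the scatter). Compound 3 is therefore estimated at 15000 nM, within 4000 nM to 60000 nM.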

Compound 3, half-maximal inhibitory concentration: 68000 nM
Estimate against measurement, compound 3: 4.5-fold (0.66 log units) below, and the stated range ends below it.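

The saturated chain carbon bound to an aromatic nitrogen turns out to matter in this assay: ethoxy in place of hydrogen there gives a 4.5-fold higher number from compound 2 to compound 3 (0.66 log units; beyond the scatter), so inhibition weakens on this read-out. Earlier, only the group on the aromatic carbon had been seen to move the number; now the other end of the molecule does too. Nothing measured here bears on why this step occurs. From the compounds shown here alone, it remains open whether the oxygen of ethoxymethyl or simply its length counts, which a butyl chain at this place could separate.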